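The source may report more compounds than this note shows. Statements on the series, on what has been measured and on what is new or still open speak of the compounds shown alone.

Compound 1 `CCc1ccc(SCc2ccc(/C=C/C(=O)Nc3ccccc3N)cc2)cc1` gives 68.6%
Compound 2 `Nc1ccccc1NC(=O)c1ccc(CSc2ccc(Br)cc2)cc1` gives 45.7%
Compound 3 `COC(=O)c1ccccc1SCc1ccc(C(=O)Nc2ccccc2N)cc1` gives 46.1%

These three numbers come from a functional assay on A549 cells (Homo sapiens) for inhibition, read by CCK-8 assay, with a stated time of 72 h, tested at 8 uM (on this read-out lower numbers stand for less inhibition of growth and higher numbers for more inhibition of growth at the one concentration tested), and are all the evidence available so far. Compound 2 at 45.7% and compound 3 at 46.1% lie within the scatter of each other, so the two cannot be ranked. Compound 1 stands above compound 2 by a gap beyond the scatter.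

Compound 4 `Nc1ccccc1NC(=O)c1ccc(CSc2ccc(Cl)cc2)cc1` has yet to be read in this assay and differs from compound 2 in one place only. That difference is chloro in place of bromo on an aromatic carbon in the terms of the structures: chloro in place of bromo on an aromatic carbon, para to a large group, so that 4-bromophenyl becomes 4-chlorophenyl.

For the measured compounds named here, no two measured compounds differ in just one place, so the data hold no measured step to set beside this one. The expectation therefore starts from compound 2 at 45.7% and favours neither direction. The estimated step of a number 0.3 percentage points higher from compound 2 to compound 4 (within the scatter) is expected to stay within the scatter. For compound 4 the expected value is 46% with an estimated range from 35% to 58% as its likely span.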

Compound 4, percent growth inhibition at one concentration: 50.4%
Compound 4: the middle estimate sits 4.4 percentage points below what was measured; the measured number falls inside the stated range.
By their numbers in this assay, from the lowest: compounds 2, 3 and 4 (each within the scatter of the next); then compound 1.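

In this assay, for the compounds shown here, the exchange of chloro for bromo on an aromatic carbon, para to a large group, gives a number 4.7 percentage points higher from compound 2 to compound 4 (within the scatter) and is the first comparison in this set that isolates a single place. Going by these compounds alone, it shows that 4-bromophenyl and 4-chlorophenyl cannot be told apart on this read-out at the one concentration tested, so this swap of one halogen for the other leaves the growth inhibition unresolved from the scatter, something the earlier compounds, none of which formed such a pair, could not show. No measurement of any property of these two compounds is available to bear on this result.

What the compounds shown leave open is how far this position tolerates change beyond these two halogens, since one pair says nothing about whether a methoxy group, an amine or a carboxylic acid in the same place would give a number that stands clear of the scatter. As far as these compounds go, it also remains open whether the same exchange would read alike at other concentrations or on other cell lines.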